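Cytotoxicity notes on a flavonol benzyl ether series

This account rests on a few compounds, and the source may have more. Where it says the series, first, only, none or still open, it means among the compounds named here.

Measured compounds:
- compound 1, `O=c1c(OCc2ccccc2Cl)c(-c2ccccc2)oc2cc(O)cc(O)c12`, > 100000 nM
- compound 2, `O=c1c(OCc2ccccc2[N+](=O)[O-])c(-c2ccccc2)oc2cc(O)cc(O)c12`, 51000 nM
- compound 3, `O=c1c(OCc2ccc(Br)cc2)c(-c2ccccc2)oc2cc(O)cc(O)c12`, 2000 nM

In an ADME assay on Huh-5-2 cells (Homo sapiens) for cytotoxicity, read by WST assay, with a stated time of 3 days (a higher number here means that more compound is tolerated, a lower number that less compound is tolerated), compound 3 gives 2000 nM. For compound 1 the value > 100000 nM is a limit of the assay, not a number (the limit of > 100000 nM in this assay, at which 1 of the 3 values shown sits). Among the two numbers shown, compound 3 sits lowest; the nearest is compound 2, a step of a 26-fold lower number from compound 2 to compound 3 (1.41 log units; beyond the scatter). From compound 1 the step is an at least 50-fold lower number from compound 1 to compound 3 (1.69 log units; beyond the scatter). The step of an at least 1.9-fold lower number from compound 1 to compound 2 (0.29 log units; that floor lies within the scatter) lies within the scatter.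

Compound 4 is `N#Cc1ccc(COc2c(-c3ccccc3)oc3cc(O)cc(O)c3c2=O)cc1`. It differs from compound 3 by cyano in place of bromo on an aromatic carbon. Within the data shown here, the measured steps that bear on the benzyl ring are an at least 50-fold lower number from compound 1 to compound 3 (1.69 log units; beyond the scatter) and a 26-fold lower number from compound 2 to compound 3 (1.41 log units; beyond the scatter), both large, but each changes the position as well as the group, so no step isolates a swap of one group against another at the same position. The direction of the step from compound 3 to compound 4 is therefore open; the expected step is a 3.0-fold higher number from compound 3 to compound 4 (0.48 log units; beyond the scatter). For compound 4 the estimated value in this assay is 6000 nM, with a range from 1500 nM to 30000 nM.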

Compound 4, half-maximal cytotoxic concentration: 48000 nM
Beside the measured number, compound 4's estimate is 8.0-fold (0.90 log units) below it, outside the stated range (above it).
By their numbers in this assay, from the lowest: compound 3; then compounds 4 and 2 (each within the scatter of the next). At a limit, above all of these: compound 1.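

a 24-fold higher number from compound 3 to compound 4 (1.38 log units; beyond the scatter) in this assay: this is the first step in the series that swaps one group for another at the same place on the benzyl ring, and it shows that the choice of group at this place alone can move the number by a large margin. With cyano at this place the low number of compound 3 is gone, giving a 1.1-fold lower number from compound 2 to compound 4 (0.03 log units; within the scatter) and an at least 2.0-fold lower number from compound 1 to compound 4 (0.31 log units; beyond the scatter). The value of compound 1 is a limit and not a number: the limit of > 100000 nM in this assay, at which 1 of the 4 values shown sits.

Open, going by these compounds, is whether the low number stays with bromo alone, or also appears with an amine or a carboxylic acid at this place. Also open, on these data alone, is whether cyano would keep its number at the place held by chloro in compound 1 and by nitro in compound 2.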